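The source may report more compounds than this note shows. Statements on the series, on what has been measured and on what is new or still open speak of the compounds shown alone.

Compound 1 `Oc1ccc(-c2nc3cc(C(F)(F)F)ccc3[nH]2)cc1`; compound 2 `CCN(CC)CC(=O)Nc1ccc(-c2nc3cc(C(F)(F)F)ccc3n2C)cc1`; compound 3 `COc1ccc(-c2nc3cc(C(F)(F)F)ccc3[nH]2)cc1`; compound 4 `CCN(CC)CC(=O)Nc1ccc(-c2nc3cc(C(F)(F)F)ccc3[nH]2)cc1` (not yet measured).

In an ADME assay on Vero cells (Chlorocebus sabaeus) for cytotoxicity (on this read-out lower numbers stand for higher toxicity in this test and higher numbers for lower toxicity in this test), compound 1 gives only a limit, > 100000 nM. Compound 2 gives 90000 nM in this assay. Compound 3 gives 15000 nM in this assay, and so stands lowest of the two numbers shown, its nearest neighbour being compound 2 with a number higher by a margin beyond the scatter. Among the measured compounds shown here, the one step measured with a single change is an at least 6.6-fold lower number from compound 1 to compound 3 (0.82 log units; beyond the scatter), resting on (the limit of > 100000 nM in this assay, at which 1 of the 3 values shown sits).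

Compound 4 differs from compound 3 by (((diethylamino)methyl)carbonyl)amino in place of methoxy on an aromatic carbon. The measured step concerns a different change and does not bear on this one directly. Compound 2 carries the same entering group on a methylated core and gives a number well above that of compound 3. From that comparison, the step of a 4.7-fold higher number from compound 3 to compound 4 (0.67 log units; beyond the scatter) is expected to go upward, beyond the scatter. Compound 4 is therefore expected to give about 70000 nM in this assay, within 25000 nM to 200000 nM.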

Compound 4, half-maximal cytotoxic concentration: 24000 nM
Estimate against measurement, compound 4: 2.9-fold (0.46 log units) above; measured number below the stated range.
By their numbers in this assay, from the lowest: compounds 3 and 4 (each within the scatter of the next); then compound 2. At a limit, above all of these: compound 1.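

In this assay the change on this aromatic carbon gives a 1.6-fold higher number from compound 3 to compound 4 (0.20 log units; within the scatter), so methoxy and (((diethylamino)methyl)carbonyl)amino cannot be told apart at this position when the aromatic nitrogen carries hydrogen. Among the compounds shown here, the high number of compound 2 goes instead with the methyl on that nitrogen, as the single change gives a 3.8-fold lower number from compound 2 to compound 4 (0.57 log units; beyond the scatter). Set against hydroxy, the same entering group gives an at least 4.1-fold lower number from compound 1 to compound 4 (0.61 log units; beyond the scatter), a step bounded on one side only, since compound 1 gives a limit: the limit of > 100000 nM in this assay, at which 1 of the 4 values shown sits.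

On these data alone, whether methyl on the aromatic nitrogen has the same effect with methoxy or hydroxy on the aromatic carbon remains open. Also open, as far as these compounds go, is whether a morpholine or a pyrrolidine in place of the diethylamino end, or a longer chain before it, would stay within the scatter of compound 4.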